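The source may hold more compounds than are shown below. What is called first, only, known or untested is meant among the compounds shown, and "the series" means these compounds.

Working notes on a pair of glycosylated lactams tested for suppression of nitrite output.

Compound 1, `O=C1C[C@H](O[C@H]2O[C@H](CO)[C@@H](O)[C@H](O)[C@@H]2O)CN1`, is the simplest member. In a functional assay on RAW264.7 cells (Mus musculus) for inhibition, read by Griess assay, with a stated time of 24 h (a higher number here means a weaker inhibitor, a lower number a stronger inhibitor), compound 1 gives 67100 nM. Compound 2, `O=C1C[C@H](O[C@H]2O[C@H](CO)[C@@H](O)[C@H](O)[C@H]2O)CN1Cc1ccccc1`, carries a benzyl group on the lactam nitrogen and a different configuration at one sugar carbon. In this assay compound 2 gives 105000 nM. Of the two numbers in hand, that of compound 2 is the higher, but the gap to compound 1 is within the scatter, so the two compounds cannot be separated on these data.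

Compound 3, `O=C1C[C@H](O[C@H]2O[C@H](CO)[C@@H](O)[C@H](O)[C@@H]2O)CN1Cc1ccccc1`, is the next compound to be measured. Relative to compound 2 the change is the two compounds have the same atoms and bonds and differ only in configuration as drawn: 1 of 6 stereo elements differ; a stereocentre at a saturated ring carbon is drawn R in compound 2 and S in compound 3. Among the measured compounds shown here, no measured pair isolates a change of this kind, so there is no step to lean on; the only comparison available, compound 1 against compound 2, shows no difference beyond the scatter. The expectation is therefore a step of about a 1.2-fold lower number from compound 2 to compound 3 (0.07 log units; within the scatter), that is, none beyond the scatter in either direction. Compound 3 is estimated at 90000 nM, with a range from 30000 nM to 250000 nM.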

Compound 3, half-maximal inhibitory concentration: 64000 nM
The estimate for compound 3 lay 1.4-fold (0.15 log units) above the measured number; measured number inside the range.
By their numbers in this assay, from the lowest: compounds 3, 1 and 2 (each within the scatter of the next).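

In this assay, changing the saturated ring carbon from R to S gives a 1.6-fold lower number from compound 2 to compound 3 (0.22 log units; within the scatter), so no effect of this stereocentre can be resolved with benzyl on the lactam nitrogen. Benzyl in place of hydrogen on the amide-type nitrogen in a ring can now be read as a single change, and it gives a 1.0-fold lower number from compound 1 to compound 3 (0.02 log units; within the scatter), so compound 1 and compound 3 cannot be separated and the added benzyl shows no effect in this assay. The stereochemical comparison is the cleaner of the earlier and new readings, since the opening pair differed in two places, and it rests on one structural fact: the fact that compounds 2 and 3 differ only in the configuration as drawn

The compounds shown leave open whether an amine, a carboxylic acid or a longer chain in place of benzyl on the lactam nitrogen would give a step beyond the scatter. They also leave open whether the same change of configuration at the saturated ring carbon would give a different result with hydrogen rather than benzyl on that nitrogen.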